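The source may hold more compounds than are shown below. What is called first, only, known or untested is meant among the compounds shown, and "the series" means these compounds.

Solubility notes on the series.

Compound 1 `Cc1cc(CN(C2CCC2)C(CC(=O)O)c2ccc(Cl)cc2)ccc1OCCn1c(=O)ccn(C)c1=O` and compound 2 `COc1cc(CN(C2CCC2)C(CC(=O)O)c2ccc(Cl)cc2)ccc1OCCn1c(=O)ccn(C)c1=O` share one core and differ only by methyl in place of methoxy on an aromatic carbon. In a physicochemical assay for solubility, at pH 1.1 (on this read-out higher numbers stand for higher solubility and lower numbers for lower solubility), compound 1 gives 3000000 nM, and in this assay compound 2 gives 3000000 nM. The step of no change at the digits printed from compound 2 to compound 1 (within the scatter) shows that methyl in place of methoxy on an aromatic carbon left the read-out unchanged within the scatter on this pair.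

Compound 3 `COc1cc(CN(CC(C)C)C(CC(=O)O)c2ccc(Cl)c(F)c2)ccc1OCCN1C(=O)CCC1=O` rests on a different core; the difference between the two cores is not broken down here. In this assay compound 3 gives 3000000 nM, level with compounds 1 and 2 within the scatter.

Compound 4 `Cc1cc(CN(CC(C)C)C(CC(=O)O)c2ccc(Cl)c(F)c2)ccc1OCCN1C(=O)CCC1=O` is not yet measured. It differs from compound 3 by methyl in place of methoxy on an aromatic carbon. This is the same kind of change as from compound 2 to compound 1, not the same change: in compound 3 the methoxy sits ortho to a 2-(2,5-dioxopyrrolidin-1-yl)ethoxy group and meta to a large group, whereas in compound 2 it sits ortho to a large group and meta to a large group.

For compound 4 the step of no change at the digits printed from compound 3 to compound 4 (within the scatter) is expected, beside the earlier no change at the digits printed from compound 2 to compound 1 (within the scatter), because that earlier step gave no change within the scatter and compound 3 itself gives 3000000 nM. Compound 4 is therefore estimated at 3000000 nM, with a range from 1500000 nM to 6000000 nM expected to hold most repeats.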

Compound 4, solubility: 3000000 nM
For compound 4 middle estimate and measured number coincide at the digits printed; low and high end bracket the measured number.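

In this assay the new step reads no change at the digits printed from compound 3 to compound 4 (within the scatter), and on the core of compound 1 the earlier step reads no change at the digits printed from compound 2 to compound 1 (within the scatter), so methyl in place of methoxy on an aromatic carbon left the read-out unchanged within the scatter on both cores shown. This is two matched pairs and no more: it shows that the change carried over once, with the methyl of compound 4 ortho to a 2-(2,5-dioxopyrrolidin-1-yl)ethoxy group and meta to a large group, but it gives no rule for other cores, other positions on the ring or other read-outs. No measurement at hand speaks to why the read-out stays level on either pair.

The compounds shown leave open how the read-out would respond to an amine, a nitrile or a longer chain on that aromatic carbon in place of methyl or methoxy. Also open, as far as these compounds go, is whether the same change would leave the read-out level on a third core, or at a pH other than the one used here, since both pairs share a single set of conditions.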